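Amide series: phenyl for the carbamate arm, compound 1 to compound 3

This account rests on a few compounds, and the source may have more. Where it says the series, first, only, none or still open, it means among the compounds named here.

Measured so far:
compound 1 `COc1ccc(N(CC(=O)NCCC[Te]c2ccccc2)C(=O)CNC(=O)OC(C)(C)C)cc1` — < 100000 nM
compound 2 `CC1=C(SCCC(=O)OCC(=O)NCCC[Te]c2ccccc2)C(=O)c2ccccc2C1=O` — 83200 nM

In a functional assay on NCI-H322M cells (Homo sapiens) for inhibition, with a stated time of 48 h (a higher number here means that more compound is tolerated, a lower number that less compound is tolerated), compound 1 gives < 100000 nM, which is a limit of the assay and not a number (the limit of < 100000 nM in this assay, at which 1 of the 2 values shown sits). Compound 2 gives 83200 nM in this assay. Among the compounds with values here, both measured compounds therefore sit at the weak end of the scale, and no step between them is computed, as they differ in more than one place.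

Compound 3 `COc1ccc(N(CC(=O)NCCC[Te]c2ccccc2)C(=O)c2ccccc2)cc1` has not yet been measured. It differs from compound 1 in that (phenyl in place of ((tert-butoxycarbonyl)amino)methyl on a carbonyl carbon), in words phenyl in place of ((tert-butoxycarbonyl)amino)methyl on a carbonyl carbon. Since compound 1 stands only at a limit (the limit of < 100000 nM in this assay, at which 1 of the 2 values shown sits), the expected step is a step that the limit leaves unreadable from compound 1 to compound 3, none beyond the usual scatter. Compound 3 is expected to give 90000 nM in this assay, with a range from 40000 nM to 200000 nM.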

Compound 3, concentration lethal to 50% of the cells: < 100000 nM
Compound 3: no number, only a limit; the forecaster's own chance of this, stated with the estimate: 45%; the middle value lies beyond the limit too.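

No step from compound 1 to compound 3 can be read, as each gives only a limit and not a number: the limit of < 100000 nM in this assay, at which 2 of the 3 values shown sit.

From the compounds shown here alone, whether phenyl in place of ((tert-butoxycarbonyl)amino)methyl on a carbonyl carbon changes the lethal concentration at all remains open.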